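The source may report more compounds than this note shows. Statements on the series, on what has been measured and on what is new or still open speak of the compounds shown alone.

Working notes on the series. In a functional assay on MCF7 cells (Homo sapiens) for cytotoxicity, read by MTT assay, with a stated time of 24 h (a lower number here means a stronger inhibitor of growth, a higher number a weaker inhibitor of growth), compound 1 (`COc1cc(/C=C/C(=O)c2ccc(OCC=C(C)C)cc2O)cc(OC)c1OC`) gives 81000 nM and compound 2 (`COc1ccc(/C=C/C(=O)c2ccc(OCC=C(C)C)cc2OCC=C(C)C)c(OC)c1OC`) gives 92000 nM in the same read-out. Within the data shown here, these are the only two numbers so far, and they lie within the scatter of each other, so compound 1 holds no separate rank.

Compound 3 (`COc1cc(/C=C/C(=O)c2ccc(OCC=C(C)C)cc2OCC=C(C)C)cc(OC)c1OC`) is still unmeasured. It differs from compound 1 by the change 3-methylbut-2-en-1-yl in place of hydrogen on an oxygen on an aromatic ring in which 3-methylbut-2-en-1-yl stands in place of hydrogen on an oxygen on an aromatic ring, read one bond further out as hydroxy to (3-methylbut-2-en-1-yl)oxy. Among the measured compounds shown here, no measured pair shows this change on its own, so the step has no direct precedent. For the measured compounds named here, the only guide is the narrow spread of the series, with compound 1 at 81000 nM and compound 2 at 92000 nM as the two anchors.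

In this assay no shift beyond the scatter is expected in either direction, and the estimated step of a 1.0-fold higher number from compound 1 to compound 3 (0.02 log units; within the scatter) stays inside it. For compound 3 the estimate is 85000 nM with an expected range from 45000 nM to 150000 nM as the likely span.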

Compound 3, concentration for 50% growth inhibition: 9000 nM
Estimate against measurement, compound 3: 9.4-fold (0.98 log units) above; the whole stated range lies above it.
By their numbers in this assay, from the lowest: compound 3; then compounds 1 and 2 (each within the scatter of the next).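

In this assay, the change from hydroxy to (3-methylbut-2-en-1-yl)oxy on the core of compound 1 gives a 9.0-fold lower number from compound 1 to compound 3 (0.95 log units; beyond the scatter). This marks the oxygen on an aromatic ring as a place where the read-out responds, something the two earlier numbers, lying within the scatter of each other, could not show. The entering 3-methylbut-2-en-1-yl brings 5 carbon atoms and 1 double bond while the hydrogen leaves, and this single pair cannot separate the loss of that hydrogen from the presence of the chain; nothing at hand gives a reason for the step.

On these data alone, the step rests on one pair in one cell line, so how far it holds on other cores of the series remains open. Also open, as far as these compounds go, is what a plain ethyl group, a saturated 3-methylbutyl chain or a longer geranyl chain on the same oxygen would give, and so whether the double bond or the chain length matters to the size of the step.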